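Inverting One Stereocentre in an Unsaturated Diamine Chain

A few compounds are considered here, and "the series" means these few. Any claim that something is new, unique, unknown or untested is made for them only; others in the source may bear on it.

Measured so far in an assay on isolated protein (strain Sprague-Dawley) for inhibition of Monoglyceride lipase (Rattus norvegicus), tested at 100 uM; on this read-out higher numbers stand for more inhibition at the one concentration tested (going by the name of the read-out) and lower numbers for less inhibition:
Compound 1 `CCCCCCCC/C=C\CCCCCC[C@@H](N)C(N)=O` gives 0%.
Compound 2 `CCCCCCCC/C=C\CCCCCC[C@@H](N)CN` gives 42.2%.

Among the measured compounds shown here, the one step measured so far is a number 42.2 percentage points higher from compound 1 to compound 2 (beyond the scatter). For the measured compounds named here, on these two numbers compound 2 stands highest, with compound 1 the only neighbour and well below it.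

Compound 3 `CCCCCCCC/C=C\CCCCCC[C@H](N)CN` is the next compound. Its difference from compound 2 is the two compounds have the same atoms and bonds and differ only in configuration as drawn: 1 of 2 stereo elements differ; a stereocentre at a saturated chain carbon is drawn R in compound 2 and S in compound 3. Going by the values given here, no measured step concerns a change of configuration at this carbon; the only step known, the swap of carbamoyl for aminomethyl, is a change of atoms, not of drawn configuration, and so says nothing about the present case. Among the compounds with values here, a change of configuration alone can leave a number unchanged or move it far, in either direction, and there is no measured pair here to say which. The estimate for compound 3 is therefore centred a little below compound 2, with a wide range, and the expected step is a number 12.2 percentage points lower from compound 2 to compound 3 (beyond the scatter). Compound 3 is estimated at 30%, between 5% and 55%.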

Compound 3, a percentage reported as inhibition, at one concentration (the size of the read-out at that concentration, not a potency): 49.9%
Estimate against measurement, compound 3: 19.9 percentage points below, and the stated range covers the measured number.
By their numbers in this assay, from the lowest: compound 1; then compounds 2 and 3 (each within the scatter of the next).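

In this assay, the drawn configuration at this saturated chain carbon shows no readable effect, with a number 7.7 percentage points higher from compound 2 to compound 3 (within the scatter). The large gain seen with aminomethyl in place of carbamoyl does not depend on compound 2 alone. The diamine with the opposite drawn configuration also stands well clear of the amide, with a number 49.9 percentage points higher from compound 1 to compound 3 (beyond the scatter). This comparison isolates the stereocentre, and its reading rests on one point: the fact that compounds 2 and 3 differ only in the configuration as drawn.

A percentage at a single concentration is not a potency, so the two diamines could still differ at other concentrations. On these data alone, it also remains open whether a carboxylic acid in place of the aminomethyl group, or a shorter chain, would keep this inhibition, and whether either configuration would then matter.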